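The compounds below may be only part of what the source reports. "The series", "measured", "known", "first", "only" and "open" are said of these compounds alone.

Working notes on the series sharing the core of compound 1 `Cc1cccc(Nc2nccc(-c3ccco3)n2)c1`. For the measured compounds named here, in a functional assay for inhibition, with Homo sapiens as the target (on this read-out higher numbers stand for weaker inhibition and lower numbers for stronger inhibition), compound 1 gives 2100 nM, the highest of the three numbers measured so far. Compound 2 `Cc1cccc(Nc2nccc(-c3ccc(C)o3)n2)c1` gives 2000 nM in this assay; the step of a 1.1-fold lower number from compound 1 to compound 2 (0.02 log units; within the scatter) is a methyl in place of hydrogen on an aromatic carbon. Compound 3 `Cc1cc(C)cc(Nc2nccc(-c3ccco3)n2)c1` gives 700 nM; the step of a 3.0-fold lower number from compound 1 to compound 3 (0.48 log units; beyond the scatter) is likewise a methyl in place of hydrogen on an aromatic carbon, here on the six-membered aromatic ring of carbon only.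

Compound 4 `c1cc(Nc2nccc(-c3ccco3)n2)cc(OCCn2ccnc2)c1` is not yet measured. Its change from compound 1 is 2-(1H-imidazol-1-yl)ethoxy in place of methyl on an aromatic carbon. Going by the values given here, no measured step removes the methyl or brings in a group of this kind; the only step touching the same six-membered aromatic ring of carbon only is a 3.0-fold lower number from compound 1 to compound 3 (0.48 log units; beyond the scatter), which added rather than replaced, so it bears only loosely. The expected step of a 1.4-fold lower number from compound 1 to compound 4 (0.15 log units; within the scatter) is therefore small and uncertain in direction. For compound 4 in this assay the estimate is 1500 nM, with a range from 400 nM to 6000 nM.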

Compound 4, half-maximal inhibitory concentration: 200 nM
Estimate against measurement, compound 4: 7.5-fold (0.88 log units) above, outside the stated range (below it).
By their numbers in this assay, from the lowest: compound 4; then compound 3; then compounds 2 and 1 (each within the scatter of the next).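

At this position, on the six-membered aromatic ring of carbon only and meta to a large group, the methyl can give way to the much larger 2-(1H-imidazol-1-yl)ethoxy without loss of inhibition: in this assay there is an 11-fold lower number from compound 1 to compound 4 (1.02 log units; beyond the scatter). The earlier steps only added a methyl, so this is the first step that replaces the group at this position, and it is the only large step from compound 1 among those shown. Nothing available bears on what lies behind this step.

Still open, on these data alone, is which part of the group carries the step: the ether oxygen, the ethoxy link or the five-membered aromatic ring. A plain methoxy, a longer chain ending in the same ring, or a chain ending in a dimethylamine or a carboxylic acid would separate these parts.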